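The source may hold more compounds than are shown below. What is called first, only, known or untested is meant among the compounds shown, and "the series" means these compounds.

Compound 1, with the structure `CCNCCn1c(N2CCN(C)CC2)nc2ccccc21`, is the weaker of the two compounds measured in a functional assay on ileum for inhibition of histamine H1 receptor (Cavia porcellus) (on this read-out lower numbers stand for stronger inhibition and higher numbers for weaker inhibition), where compound 1 gives 290 nM. Among the compounds with values here, the only other measured compound, compound 2 with the structure `CCCCCN1CCCN(c2nc3ccccc3n2CCOCC)CC1`, gives 7.4 nM in this assay, a gap that is well beyond the scatter, though the two differ in more than one place and no single step connects them. Compound 3, with the structure `COCCCn1c(N2CCN(C)CC2)nc2ccccc21`, has not yet been measured. It differs from compound 1 in one place: methoxymethyl in place of ethylamino on a saturated chain carbon, two bonds along the chain from an aromatic nitrogen. Within the data shown here, no step of this kind stands among the measured pairs, so the expected size of the change rests only on what the two measured compounds show. In this assay compound 3 is expected to give a somewhat lower number than compound 1, a step of about a 2.4-fold lower number from compound 1 to compound 3 (0.38 log units; beyond the scatter), in the direction of stronger inhibition. The estimated value for compound 3 in this assay is 120 nM, with a range from 40 nM to 400 nM.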

Compound 3, half-maximal inhibitory concentration: 860 nM
The estimate for compound 3 lay 7.2-fold (0.86 log units) below the measured number; the measured number lies above the stated range.
By their numbers in this assay, from the lowest: compound 2; then compound 1; then compound 3.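

On a saturated chain carbon, two bonds along the chain from an aromatic nitrogen, methoxymethyl in place of ethylamino gives a 3.0-fold higher number from compound 1 to compound 3 (0.47 log units; beyond the scatter) in this assay, a modest step towards weaker inhibition, so this position is not indifferent to the exchange. The two groups have the same count of heavy atoms, and they differ in that a nitrogen carrying a hydrogen-bond donor gives way to an oxygen with none. Nothing at hand gives a reason for the step.

A single exchange cannot tell whether the loss of the donor or the change of atom matters more, or whether the step depends on the rest of the molecule. Going by these compounds, a hydroxyl or a dimethylamino group at the end of the chain, or a longer chain carrying the ethylamino group, remains open.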